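The source may report more compounds than this note shows. Statements on the series, on what has been measured and on what is new or still open speak of the compounds shown alone.

In an ADME assay on HepG2 cells (Homo sapiens) for cytotoxicity, with a stated time of 72 h (on this read-out higher numbers stand for an effect only at larger amounts of compound and lower numbers for an effect already at smaller amounts), compound 1 `CCc1ccc(NC(=O)Nc2cc(C)nc3ccccc23)cc1` gives 17000 nM. Compound 2 `Cc1cc(NC(=O)Nc2ccc(C(N)=O)cc2)c2ccccc2n1` gives > 25000 nM, and this is a limit of the assay and not a number. It is the limit of > 25000 nM in this assay, at which 1 of the 2 values shown sits, so compound 2 has no exact position in the series, only this limit.

The next change leads to compound 3 `Cc1cc(NC(=O)Nc2ccc(O)cc2)c2ccccc2n1`, with hydroxy in place of carbamoyl on an aromatic carbon. The new group sits on the same ring of carbon only, para to a large group.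

For the measured compounds named here, one measured step bears on this: an at least 1.4-fold higher number from compound 1 to compound 2 (0.16 log units; that floor lies within the scatter). It replaces ethyl with carbamoyl, so it involves the group that now leaves, but it gives no reading for hydroxy. Going by the values given here, with that step as the only guide, no change beyond the scatter is expected in this assay, and the direction remains open. A reading at the same limit would fit this expectation. The expected step is an at least 1.2-fold lower number from compound 2 to compound 3 (0.09 log units; that floor lies within the scatter). The estimate for compound 3 is 20000 nM, with an expected range from 8000 nM to 40000 nM.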

Compound 3, half-maximal effective concentration: > 25000 nM
Compound 3: no number, only a limit (the forecaster's own chance of this, stated with the estimate: 45%); at least 1.2-fold (0.09 log units) between middle value and limit.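

In this assay compound 3 gives > 25000 nM, which is a limit of the assay and not a number. With hydroxy, which has fewer heavy atoms than carbamoyl, para to a large group, the series again ends at the limit, and the step between these two groups cannot be read: the limit of > 25000 nM in this assay, at which 2 of the 3 values shown sit. Against ethyl, the reading is an at least 1.4-fold higher number from compound 1 to compound 3 (0.16 log units; that floor lies within the scatter), so that neither hydroxy nor carbamoyl is shown to move the number beyond the scatter at this place.

From the compounds shown here alone, how far compound 2 and compound 3 lie from each other stays open, and so does how far either truly lies from compound 1. Also open, going by these compounds, is whether an amine, a carboxylic acid or a longer chain on the same aromatic carbon would give an exact number in this assay, or a step beyond the scatter from compound 1.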